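The source may hold more compounds than are shown below. What is called first, only, known or untested is meant among the compounds shown, and "the series" means these compounds.

In a functional assay on HCT-116 cells (Homo sapiens) for antiproliferative activity, read by sulforhodamine B assay, with a stated time of 72 h (a higher number here means a weaker inhibitor, a lower number a stronger inhibitor), three compounds on a shared core have been measured. Compound 1 (`COc1ncc(-c2ccc3ncnc(Nc4ccc(OCCO)cc4)c3c2)cc1NS(=O)(=O)c1ccc(F)cc1F`) gives 1060 nM and compound 3 (`COc1ncc(-c2ccc3ncnc(Nc4ccc(OCCO)nc4)c3c2)cc1NS(=O)(=O)c1ccc(F)cc1F`) gives 2340 nM, while compound 2 (`COc1ncc(-c2ccc3ncnc(Nc4ccc(OCCO)nc4)c3c2)cc1NS(C)(=O)=O`) gives 5360 nM as the highest number of the three. Compound 4 (`COc1ncc(-c2ccc3ncnc(Nc4ccc(OCCO)cc4)c3c2)cc1NS(C)(=O)=O`) has not yet been measured. It differs from compound 2 in one place, on a nitrogen on an aromatic ring, where 4-(2-hydroxyethoxy)phenyl stands in place of 6-(2-hydroxyethoxy)pyridin-3-yl (4-(2-hydroxyethoxy)phenyl in place of 6-(2-hydroxyethoxy)pyridin-3-yl on a nitrogen on an aromatic ring). The nearest evidence is the same exchange run the other way, with 2,4-difluorophenyl on the sulfonyl sulfur (a 2.2-fold higher number from compound 1 to compound 3 (0.34 log units; beyond the scatter)), a modest step beyond the scatter. The step at the sulfonyl sulfur itself (a 2.3-fold lower number from compound 2 to compound 3 (0.36 log units; beyond the scatter)) is of similar size but concerns another place, so it bears on the new step only indirectly. One pair cannot show that the exchange carries over to the methyl compounds, but a modest fall in the number is expected, estimated as a 2.2-fold lower number from compound 2 to compound 4 (0.35 log units; beyond the scatter) in this assay here. For compound 4 the expected value is 2400 nM (estimated range 1100 nM to 5000 nM).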

Compound 4, half-maximal inhibitory concentration: 4860 nM
Compound 4: the middle estimate sits 2.0-fold (0.31 log units) below what was measured; measured number inside the range.
By their numbers in this assay, from the lowest: compound 1; then compound 3; then compounds 4 and 2 (each within the scatter of the next).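

In this assay, with methyl on the sulfonyl sulfur, the exchange on the nitrogen on an aromatic ring gives no readable change, the step being a 1.1-fold lower number from compound 2 to compound 4 (0.04 log units; within the scatter). The step seen earlier with 2,4-difluorophenyl is therefore not repeated at the same size in the methyl compounds, yet the two steps cannot be told apart: the same change on two cores in this assay, a 2.2-fold higher number (0.34 log units; beyond the scatter) from compound 1 to compound 3 and a 1.1-fold higher number (0.04 log units; within the scatter) from compound 4 to compound 2, 2.0-fold (0.30 log units) apart, within the scatter of two such steps. At the sulfonyl sulfur, the change now holds with 4-(2-hydroxyethoxy)phenyl as well, where it gives a 4.6-fold higher number from compound 1 to compound 4 (0.66 log units; beyond the scatter), so both pairs run the same way: the same change on two cores in this assay, a 2.3-fold lower number (0.36 log units; beyond the scatter) from compound 2 to compound 3 and a 4.6-fold lower number (0.66 log units; beyond the scatter) from compound 4 to compound 1, 2.0-fold (0.30 log units) apart, within the scatter of two such steps.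

The compounds shown leave open whether a longer chain in place of the 2-hydroxyethoxy group, or an amine or a carboxylic acid at its end, would move the number. They also leave open how a cyclopropyl group or a simple phenyl on the sulfonyl sulfur would compare with methyl and 2,4-difluorophenyl.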